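The compounds below may be only part of what the source reports. "The series", "measured", "known", "first", "only" and "open" are said of these compounds alone.

Of the compounds shown here, two share one core and have been measured in a functional assay on BT-474 cells (Homo sapiens) for inhibition; a higher number here means a weaker inhibitor, a lower number a stronger inhibitor. Compound 1 `COc1c(C)cnc(CN2c3nc(N)nc(Cl)c3NC(=O)[C@@H]2C(C)C)c1C` gives 760 nM in this assay. Compound 2 `COc1c(C)cnc(CN2c3nc(N)nc(Cl)c3NC(=O)[C@H]2C)c1C` gives 410 nM in this assay, the lowest of the two numbers, with compound 1 standing within the scatter of it, so nothing separates the two beyond the usual spread of the method. The account now moves from compound 2 to compound 3 `COc1c(C)cnc(CN2c3nc(N)nc(Cl)c3NC(=O)[C@@H]2C)c1C`, which differs from it in this way: the two compounds have the same atoms and bonds and differ only in configuration as drawn: 1 of 1 stereo elements differ; a stereocentre at a saturated ring carbon is drawn R in compound 2 and S in compound 3. Among the compounds with values here, no measured pair of this kind is available, so the size of the step can only be anticipated. With a single stereocentre inverted, the expectation is that compound 3 comes out weaker than compound 2, by a step of a 7.3-fold higher number from compound 2 to compound 3 (0.86 log units; beyond the scatter) expected to exceed the scatter. Compound 3 is therefore estimated at 3000 nM in this assay, within a range from 800 nM to 15000 nM.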

Compound 3, half-maximal inhibitory concentration: 470 nM
Beside the measured number, compound 3's estimate is 6.4-fold (0.81 log units) above it; the measured number lies below the stated range.
By their numbers in this assay, from the lowest: compounds 2, 3 and 1 (each within the scatter of the next).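

In this assay, the stereocentre at the saturated ring carbon can be drawn R or S without the read-out leaving the scatter, with a 1.1-fold higher number from compound 2 to compound 3 (0.06 log units; within the scatter). The same holds for methyl in place of isopropyl on that carbon, with a 1.6-fold lower number from compound 1 to compound 3 (0.21 log units; within the scatter), so neither the configuration nor the choice between these two groups separates the compounds at this position. The reading of the first pair as a test of configuration alone rests on one point: the fact that compounds 2 and 3 differ only in the configuration as drawn

The compounds shown leave open whether a different group on this ring carbon, such as a phenyl ring, a longer chain or a carboxylic acid, would move the number beyond the scatter. Within the data shown here, they also leave open whether configuration would count with any group other than methyl, the only group seen here in both drawn forms.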